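The source may report more compounds than this note shows. Statements on the series, on what has been measured and on what is new or still open speak of the compounds shown alone.

Working notes on the series. Compound 1 `CCC1(Cc2ccccc2)OS(=O)(=O)C=C1OCc1ccccc1` is the parent: in an ADME assay on HEL cells (Homo sapiens) for cytotoxicity, with a stated time of 3 days (on this read-out higher numbers stand for lower toxicity in this test and lower numbers for higher toxicity in this test), compound 1 gives 200000 nM, the highest of the two numbers measured. Compound 3 `CCC1(Cc2ccccc2)OS(=O)(=O)C=C1OCc1ccccc1Cl` carries chloro in place of hydrogen on an aromatic carbon and gives 38000 nM in this assay; the step of a 5.3-fold lower number from compound 1 to compound 3 (0.72 log units; beyond the scatter) is modest. Compound 2 `CCC1(Cc2ccccc2)OS(=O)(=O)C=C1OCc1ccc([N+](=O)[O-])cc1` carries nitro in place of hydrogen on an aromatic carbon, and its value in this assay, < 200000 nM, is a limit of the assay rather than a number (the limit of < 200000 nM in this assay, at which 1 of the 3 values shown sits). The step of a number no higher from compound 1 to compound 2 (the limit leaves the size open) therefore has no readable size.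

Compound 4 `CCCC1(Cc2ccccc2)OS(=O)(=O)C=C1OCc1ccccc1` differs from compound 1 by methyl in place of hydrogen on a saturated chain carbon, two bonds along the chain from a saturated ring carbon. Among the measured compounds shown here, both measured steps replace a hydrogen on an aromatic carbon; neither touches the saturated chain, so no measured step bears on this change. A step within the scatter, no change at the digits printed from compound 1 to compound 4 (within the scatter), is expected. Compound 4 is estimated at 200000 nM in this assay, within 80000 nM to 400000 nM.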

Compound 4, half-maximal cytotoxic concentration: 200000 nM
The estimate for compound 4 equals the measured number at the digits printed; measured number inside the range.
By their numbers in this assay, from the lowest: compound 3; then compounds 1 and 4 (each within the scatter of the next).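

The saturated chain now has a measured step: ethyl to propyl, with methyl in place of hydrogen two bonds along the chain from a saturated ring carbon, gives no change at the digits printed from compound 1 to compound 4 (within the scatter) in this assay. The earlier readable step lay on an aromatic carbon, so this position tolerates one added methyl in this test, with compound 4 showing no shift. Nothing measured here gives a reason for this result.

From the compounds shown here alone, whether a longer chain such as butyl would behave likewise stays open. So does the effect of an amine or a carboxylic acid at this position.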